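A few compounds are considered here, and "the series" means these few. Any claim that something is new, unique, unknown or untested is made for them only; others in the source may bear on it.

Among the compounds with values here, in a functional assay on MCF7 cells (Homo sapiens) for antiproliferative activity, read by MTT assay, with stated times of 24 h and 72 h (on this read-out lower numbers stand for stronger inhibition and higher numbers for weaker inhibition), compound 1 (`COc1cc(N2C(=O)[C@@H](Oc3ccccc3)[C@H]2c2ccc3ccccc3c2)cc(OC)c1OC`) gives 282000 nM and compound 2 (`COc1cc(N2C(=O)[C@@H](Oc3ccccc3)[C@H]2c2ccc([S+](C)[O-])cc2)cc(OC)c1OC`) gives 20000 nM as the lower of the only two numbers so far, so compound 2 is the stronger inhibitor of the pair. Compound 3 (`COc1cc(N2C(=O)[C@@H](Oc3ccccc3)[C@H]2c2ccc(O)cc2)cc(OC)c1OC`) keeps the shared core of compound 2 and changes one place: one oxygen atom in place of a group of 3 heavy atoms (1 carbon, 1 oxygen, 1 sulfur; no ring), on an aromatic carbon and the incoming hydroxy group sits on an aromatic carbon of a six-membered aromatic ring of carbon only, para to a large group. Within the data shown here, one measured step bears on this, and only loosely: a 14-fold lower number from compound 1 to compound 2 (1.15 log units; beyond the scatter) and it exchanged the whole group on a saturated ring carbon. Among the measured compounds shown here, the new change replaces just one substituent within that group, and no measured pair isolates such a swap. The data therefore give no firm direction, and no step beyond the scatter is expected in this assay although the uncertainty is wide. The expected change is a 1.3-fold lower number from compound 2 to compound 3 (0.12 log units; within the scatter) as an estimate only. Compound 3 is estimated at 15000 nM with an expected range from 2500 nM to 90000 nM in this estimate.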

Compound 3, half-maximal inhibitory concentration: 48000 nM
For compound 3 the middle estimate is 3.2-fold (0.51 log units) below the measured one, and the stated range covers the measured number.
By their numbers in this assay, from the lowest: compound 2; then compound 3; then compound 1.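

In this assay, the single-substituent swap on the aromatic carbon, para to a large group, gives a 2.4-fold higher number from compound 2 to compound 3 (0.38 log units; beyond the scatter), so hydroxy in place of the group of 3 heavy atoms carrying sulfur moves the number modestly but beyond the scatter. The earlier step could not show this, as it exchanged the whole group on the saturated ring carbon, whereas this one shows that the read-out responds to a change in one substituent alone. The second new step, 4-hydroxyphenyl in place of naphthalen-2-yl, gives a 5.9-fold lower number from compound 1 to compound 3 (0.77 log units; beyond the scatter), so both compounds with a single aromatic ring at this carbon have lower numbers than the two-ring compound 1, although no information here accounts for either difference.

As far as these compounds go, with only two substituents compared on that aromatic carbon, it remains open whether a small group such as an amine, or a charged one such as a carboxylic acid, would give a lower or a higher number than either of them. The compounds shown also leave open whether these steps would keep their size and direction if the phenoxy group on the shared core were replaced by, for example, a longer chain.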